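Amine exchange on the shared core: compound 1 to 3

This account rests on a few compounds, and the source may have more. Where it says the series, first, only, none or still open, it means among the compounds named here.

Going by the values given here, compound 1 `CCc1nc(-c2ccc(Cl)cc2Cl)c(CC)nc1NC(COC)COC` holds the only full number of the set in an in vitro ADME assay on microsomes (Rattus norvegicus) for metabolic stability (a lower number here means that the compound disappears faster, a higher number that the compound lasts longer), where compound 1 gives 0.0417 h. Compound 2 `CCc1nc(-c2ccc(C)cc2OC)c(CC)nc1NC(CC)CC` returns in this assay only a limit of the assay, < 0.0167 h. One of the two values shown thus sits at a limit (the limit of < 0.0167 h in this assay, at which 1 of the 2 values shown sits). Compound 3 `CCc1nc(-c2ccc(Cl)cc2Cl)c(CC)nc1NC(CC)CC` is not yet measured; it differs from compound 1 in one place (pentan-3-yl in place of 2-methoxy-1-(methoxymethyl)ethyl on a nitrogen on an aromatic ring). Among the compounds with values here, no step between measured compounds is available, so the size of such a change in this assay cannot be read directly from the set. Compound 3 carries the same pentan-3-yl group that compound 2 bears, and compound 2 sits at the limit (the limit of < 0.0167 h in this assay, at which 1 of the 2 values shown sits), so a step downward from compound 1, beyond the usual scatter, is expected, estimated as a 2.1-fold lower number from compound 1 to compound 3 (0.32 log units; beyond the scatter). Compound 3 is expected at 0.02 h, in the range 0.008 h to 0.05 h, with a fair chance that only a limit is reported.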

Compound 3, half-life: 0.07 h
Compound 3: middle estimate off by 3.5-fold (0.54 log units), on the low side, and the stated range ends below it.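

In this assay, the exchange of 2-methoxy-1-(methoxymethyl)ethyl for pentan-3-yl on a nitrogen on an aromatic ring gives a 1.7-fold higher number from compound 1 to compound 3 (0.22 log units; within the scatter), so on this core the two side chains cannot be told apart and the oxygen atoms of the leaving group can go without a step beyond the scatter. With pentan-3-yl in place, compound 3 gives 0.07 h, a full number. This group on the shared core thus does not by itself lead to a limit of the assay. Nothing measured in the set bears on a reason for this step.

Compound 2 differs from compound 3 in more than one place, so no single change can be read from that pair. On these data alone, whether a ring amine such as morpholine or a longer chain such as heptan-4-yl on this nitrogen would stay within the scatter of these values remains open.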